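The compounds below may be only part of what the source reports. "The series", "measured", "known", "first", "only" and "open" are said of these compounds alone.

Four compounds share one core, a fully acetylated sugar carrying a side chain that ends in a ketone and an aromatic group. Compound 1 `CC(=O)OC[C@H]1O[C@@H](CC(=O)/C=C/c2ccc(Cl)cc2)[C@H](OC(C)=O)[C@@H](OC(C)=O)[C@@H]1OC(C)=O` bears a 4-chlorophenyl group on that chain, compound 2 `CC(=O)OC[C@H]1O[C@@H](CC(=O)/C=C/c2ccc3ccccc3c2)[C@H](OC(C)=O)[C@@H](OC(C)=O)[C@@H]1OC(C)=O` a naphthalen-2-yl group, compound 3 `CC(=O)OC[C@H]1O[C@@H](CC(=O)/C=C/c2ccc(C(F)(F)F)cc2)[C@H](OC(C)=O)[C@@H](OC(C)=O)[C@@H]1OC(C)=O` a 4-(trifluoromethyl)phenyl group, and compound 4 `CC(=O)OC[C@H]1O[C@@H](CC(=O)/C=C/c2ccc(Cl)c(Cl)c2)[C@H](OC(C)=O)[C@@H](OC(C)=O)[C@@H]1OC(C)=O` a 3,4-dichlorophenyl group.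

In an ADME assay on cells (Epithelial cell, Homo sapiens) for cytotoxicity, read by MTT assay, with a stated time of 24 h (on this read-out lower numbers stand for higher toxicity in this test and higher numbers for lower toxicity in this test), compound 3 gives 103 nM. In this assay, going by the values given here, compound 1 gives "not determined" (no result reported), and compound 2 gives "not determined" (no result reported), so compound 2 stands without a number of its own, and no measured step involving it can be counted.

The change from compound 2 to compound 4 is 3,4-dichlorophenyl in place of naphthalen-2-yl on a double-bonded chain carbon bound to a double-bonded chain carbon. Among the compounds with values here, with no measured step between these two compounds, and no value for compound 2 at all, the size and direction of this step in this assay cannot be read from the data; the only anchor is compound 3, whose aromatic group is also a single substituted phenyl ring.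

Compound 4 is therefore expected to land near compound 3, at an estimated 120 nM, within a range of 40 nM to 400 nM.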

Compound 4, half-maximal cytotoxic concentration: 25.8 nM
Estimate against measurement, compound 4: 4.7-fold (0.67 log units) above; measured number outside the range, below it.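

Replacing 4-(trifluoromethyl)phenyl with 3,4-dichlorophenyl on a double-bonded chain carbon bound to a double-bonded chain carbon gives a 4.0-fold lower number from compound 3 to compound 4 (0.60 log units; beyond the scatter) in this assay, and this step lies beyond the usual scatter. Going by these compounds alone, it is the first readable comparison in this set, and it shows that the read-out responds to which substituted phenyl ring sits at this position while the rest of the molecule stays the same, with the lower number here standing for higher toxicity in this test. Nothing available explains why the number falls with this change.

Within the data shown here, compound 1 and compound 2 have no number in this assay, so no step involving either can be read, and what the second chlorine adds to the 4-chlorophenyl group of compound 1, or how the naphthalen-2-yl group of compound 2 compares, remains open. The compounds shown also leave open how the read-out would respond to a phenyl ring carrying a methoxy group, an amine or a carboxylic acid at this same place.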